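The compounds below may be only part of what the source reports. "The series", "measured", "known", "first", "only" and "open" are said of these compounds alone.

In an assay on HEK293 cells for inhibition of N-acylethanolamine-hydrolyzing acid amidase (Homo sapiens), read by scintillation counting, tested at 50 uM (on this read-out lower numbers stand for less inhibition and higher numbers for more inhibition at the one concentration tested (going by the name of the read-out)), compound 2 `CCCCCCCCCCCCCCCCOC(=O)c1ccc([N+](=O)[O-])cc1` gives 26%, the higher of the two numbers seen so far, while compound 1 `CCCCCCCCCCCCCCCCOC(=O)C1CCCC1` gives 17%. Going by the values given here, the only measured step, a number 9 percentage points higher from compound 1 to compound 2 (within the scatter), falls within the scatter. Compound 3 `CCCCCCCCCCCCCCCCOC(=O)c1ccc(OC)cc1` differs from compound 2 in one place: methoxy in place of nitro on an aromatic carbon. Among the compounds with values here, no measured step touches this change, so nothing beyond the scatter is expected, and compound 3 is estimated at 22% in this assay, within 5% to 40%. The expected step is therefore a number 4 percentage points lower from compound 2 to compound 3 (within the scatter).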

Compound 3, a percentage reported as inhibition, at one concentration (the size of the read-out at that concentration, not a potency): "not active" (no number reported)
For compound 3 the study gives words and no number, and the estimate cannot be compared.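

Going by these compounds alone, compound 3 carries words and no number, so no step from compound 2 to compound 3 can be read. No measured evidence bears on this result. The compounds shown leave open how far methoxy in place of nitro changes the reading in this assay on this shared core.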